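The source may hold more compounds than are shown below. What is called first, only, known or untested is meant among the compounds shown, and "the series" means these compounds.

Measured compounds:
compound 1 `N#Cc1c(Cl)nc(SCc2nc3ccccc3[nH]2)nc1-c1ccccc1` — 3.2 nM
compound 2 `N#Cc1c(Nc2ccccc2)nc(SCc2nc3ccccc3[nH]2)nc1-c1ccccc1` — 4.46 nM

In a functional assay on SF-268 cells (Homo sapiens) for cytotoxicity, read by MTT assay, with a stated time of 3 days (on this read-out lower numbers stand for stronger inhibition and higher numbers for weaker inhibition), compound 2 gives 4.46 nM and stands alongside compound 1, separated only by a 1.4-fold higher number from compound 1 to compound 2 (0.14 log units; within the scatter). Compound 3 `N#Cc1c(Nc2ccccn2)nc(SCc2nc3ccccc3[nH]2)nc1-c1ccccc1` differs from compound 2 by pyridin-2-yl in place of phenyl on a nitrogen on an aromatic ring. Among the measured compounds shown here, no measured step exchanges phenyl for pyridin-2-yl on that nitrogen; the single step known, a 1.4-fold higher number from compound 1 to compound 2 (0.14 log units; within the scatter), alters the substituent at the same position and stays within the scatter. Compound 3 is therefore expected to remain close to compound 2, with a step of a 1.1-fold higher number from compound 2 to compound 3 (0.05 log units; within the scatter) in this assay. The estimate for compound 3 is 5 nM, within the range 2 nM to 12 nM.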

Compound 3, half-maximal inhibitory concentration: 6.75 nM
Compound 3: middle estimate off by 1.4-fold (0.13 log units), on the low side; measured number inside the range.
By their numbers in this assay, from the lowest: compounds 1, 2 and 3 (each within the scatter of the next, the first and the last beyond it).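

In this assay the change at this nitrogen, pyridin-2-yl for phenyl, brings in a ring nitrogen and the hydrogen-bond acceptor counted with it, and gives a 1.5-fold higher number from compound 2 to compound 3 (0.18 log units; within the scatter) without leaving the scatter. Set against the chloro compound, the (pyridin-2-yl)amino group gives a 2.1-fold higher number from compound 1 to compound 3 (0.32 log units; beyond the scatter) and so opens the first modest gap in this small set. Nothing available explains either step. The compounds shown leave open whether a pyridin-3-yl or pyridin-4-yl ring on that nitrogen would stay as close to compound 2, and what a simple methyl group there would do.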